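The compounds below may be only part of what the source reports. "The series", "measured", "known", "first", "only" and "open" are said of these compounds alone.

Among the measured compounds shown here, in a functional assay (blood) for inhibition, with Homo sapiens as the target (on this read-out higher numbers stand for weaker inhibition and lower numbers for stronger inhibition), compound 2 `CC(C)(C)Sc1c(CC(C)(C)C(=O)O)n(Cc2ccc(Cl)cc2)c2ccc(OCc3nc4ccccc4s3)cc12` gives 260 nM as the only actual number so far. Compound 1 `CC(C)(C)Sc1c(CC(C)(C)C(=O)O)n(Cc2ccc(Cl)cc2)c2ccc(OCc3ccc4cccnc4n3)cc12` reads > 3000 nM and that is a limit of the assay. Compound 3 `CC(C)(C)Sc1c(CC(C)(C)C(=O)O)n(Cc2ccc(Cl)cc2)c2ccc(OCc3nc4cc(C(F)(F)F)ccc4s3)cc12` differs from compound 2 by trifluoromethyl in place of hydrogen on an aromatic carbon in one place, trifluoromethyl in place of hydrogen on an aromatic carbon. For the measured compounds named here, the only measured step is an at least 11-fold lower number from compound 1 to compound 2 (1.06 log units; beyond the scatter) and it exchanges a whole group on the chain carbon, so it gives no size for a single added group. The expected step is small, a 1.3-fold lower number from compound 2 to compound 3 (0.11 log units; within the scatter) in this assay with wide uncertainty. In this assay the estimated value for compound 3 is 200 nM with an expected range from 70 nM to 600 nM for now.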

Compound 3, half-maximal inhibitory concentration: > 3000 nM
Compound 3: only a limit was reported; the forecaster's own chance of this, stated with the estimate: 10%; middle value at least 15-fold (1.17 log units) from the limit.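

In this assay, trifluoromethyl in place of hydrogen on an aromatic carbon gives an at least 11-fold higher number from compound 2 to compound 3 (1.06 log units; beyond the scatter). The earlier step exchanged a whole group on the chain carbon, whereas this one shows that a single group on the six-membered aromatic ring of carbon only can carry the series out of the measurable range. The reading for compound 3 is a limit, so the step has no upper size: the limit of > 3000 nM in this assay, at which 2 of the 3 values shown sit.

From the compounds shown here alone, whether methyl, chlorine or an amine on the same aromatic carbon would keep a number close to that of compound 2 stays open. Also open, going by these compounds, is whether trifluoromethyl on another carbon of that ring behaves like compound 3.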